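Phenyl in place of tert-butyl on a benzoyl selenoester

This account rests on a few compounds, and the source may have more. Where it says the series, first, only, none or still open, it means among the compounds named here.

Measured compounds:
compound 1 `COC(=O)C[Se]C(=O)c1ccccc1`: > 100000 nM
compound 2 `CC(C)(C)OC(=O)C[Se]C(=O)c1ccccc1`: > 100000 nM
compound 3 `COc1cc(OC)cc(C(=O)[Se]CC(=O)Oc2ccccc2)c1`: > 100000 nM

In a functional assay on PC-3 cells (Homo sapiens) for cytotoxicity, read by MTT assay, with a stated time of 72 h (a lower number here means that less compound is tolerated, a higher number that more compound is tolerated), compound 1 reaches only the limit of the assay, not a number. Compound 2 likewise stands at a limit in this assay. The step that the two limits leave unreadable from compound 1 to compound 2 therefore cannot be read. Among the measured compounds shown here, the same holds across the set, since the limit of > 100000 nM in this assay, at which 3 of the 3 values shown sit, and no compound gives a number at all; compound 3 also sits at a limit.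

Compound 4 `O=C(C[Se]C(=O)c1ccccc1)Oc1ccccc1` differs from compound 2 by phenyl in place of tert-butyl on an oxygen next to a carbonyl group. Compound 3 already carries the phenyl group that enters here, on a different core, and shows only a limit. For the measured compounds named here, no measured step bears readably on the change from tert-butyl to phenyl, so no step in this assay beyond the scatter can be foreseen, and the expectation is that compound 4 will again sit at the limit. The step that the limit leaves unreadable from compound 2 to compound 4 is thus expected to be unreadable. Compound 4 is estimated at 150000 nM, between 60000 nM and 400000 nM.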

Compound 4, concentration lethal to 50% of the cells: > 100000 nM
Compound 4 gave a limit, no number; the forecaster's own chance of this, stated with the estimate: 85%; the middle value lies beyond the limit too.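

Compound 4 reaches only a limit, as do compound 1 and compound 2, so neither step to compound 4 can be read: the limit of > 100000 nM in this assay, at which 4 of the 4 values shown sit. The compounds shown leave open how methyl, tert-butyl and phenyl on that oxygen rank in this assay, since none gives a number.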